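Chloro Replaces Methoxy on the Outer Aryl Piperazine

The source may hold more compounds than are shown below. What is called first, only, known or untested is meant among the compounds shown, and "the series" means these compounds.

Three compounds share one core and differ only in the aryl group on the outer piperazine nitrogen. Compound 1 `O=C(CN1CCN(c2ccccc2)CC1)N1CCN(c2nnc(-c3ccc(Cl)cc3)c(-c3ccc(Cl)cc3)n2)CC1` carries an unsubstituted phenyl, and in a functional assay on MCF7 cells (Homo sapiens) for cytotoxicity, read by MTT assay, with a stated time of 24 h (a higher number here means a weaker inhibitor, a lower number a stronger inhibitor), compound 1 reaches only the assay limit of > 850000 nM. Compound 2 `COc1ccccc1N1CCN(CC(=O)N2CCN(c3nnc(-c4ccc(Cl)cc4)c(-c4ccc(Cl)cc4)n3)CC2)CC1` gives 330000 nM in this assay, and compound 3 `COc1cccc(N2CCN(CC(=O)N3CCN(c4nnc(-c5ccc(Cl)cc5)c(-c5ccc(Cl)cc5)n4)CC3)CC2)c1` gives 149000 nM. Among the numbers actually measured, compound 3 stands lowest; the step of a 2.2-fold lower number from compound 2 to compound 3 (0.35 log units; beyond the scatter) is modest, while the steps of an at least 2.5-fold lower number from compound 1 to compound 2 (0.41 log units; beyond the scatter) and an at least 5.7-fold lower number from compound 1 to compound 3 (0.75 log units; beyond the scatter) both run from the limit downward and are at least modest. Compound 4 `O=C(CN1CCN(c2cccc(Cl)c2)CC1)N1CCN(c2nnc(-c3ccc(Cl)cc3)c(-c3ccc(Cl)cc3)n2)CC1` is not yet measured. It differs from compound 3 by chloro in place of methoxy on an aromatic carbon. For the measured compounds named here, none of the measured steps exchanges one substituent for another on this ring: each either adds a methoxy to the bare phenyl or moves it, and all were modest or at most modest in size. Going by the values given here, no measured step therefore bears directly on the change to chloro, and the author expects a step in this assay no larger than those already seen, most likely within the scatter. Compound 4 is estimated at 150000 nM, with a range from 50000 nM to 450000 nM. The step of a 1.0-fold higher number from compound 3 to compound 4 (0.00 log units; within the scatter) is accordingly expected to remain within the scatter.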

Compound 4, half-maximal inhibitory concentration: > 803000 nM
Compound 4 was reported as a limit; the forecaster's own chance of this, stated with the estimate: 10%; middle value at least 5.3-fold (0.72 log units) from the limit.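

In this assay, for the compounds shown here, the exchange of chloro for methoxy on this aromatic carbon, meta to a large group, gives an at least 5.3-fold higher number from compound 3 to compound 4 (0.73 log units; beyond the scatter), which shows for the first time that the identity of the substituent at this place matters, and not only whether one is present. The 3-chlorophenyl compound also falls short of the compound with the methoxy on the other ring position, with an at least 2.4-fold higher number from compound 2 to compound 4 (0.38 log units; beyond the scatter), so among the four compounds shown only the two bearing a methoxy give a measured number rather than a limit. Compound 4 is reported only as a limit, and compound 1 is a limit too, so the step between them cannot be read: the limit of > 803000 nM in this assay, at which 1 of the 4 values shown sits.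

From the compounds shown here alone, how far the true value of compound 4 lies from its limit remains open, and with it the full size of the loss on leaving methoxy. Also open, going by these compounds, is how a hydroxyl, an ethoxy or an amine would read at this same place, which would tell whether the oxygen of the methoxy or the whole group is what separates compound 3 from compound 4.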